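One Swap Repeated, Three Compounds at the Assay Limit

This account rests on a few compounds, and the source may have more. Where it says the series, first, only, none or still open, it means among the compounds named here.

In an assay on isolated protein for inhibition of malate dehydrogenase, mitochondrial (Sus scrofa), with stated times of 45 min and 30 min; a higher number here means a weaker inhibitor, a lower number a stronger inhibitor:
Compound 1 `COc1ccc(S(=O)(=O)Nc2ccc3oc(-c4ccccc4)nc3c2)cc1` gives > 63000 nM, a limit of the assay.
Compound 2 `O=S(=O)(Nc1ccc2oc(-c3ccccc3)nc2c1)c1ccc(C(F)(F)F)cc1` gives > 63000 nM, likewise a limit.
Compound 3 `O=S(=O)(Nc1ccc(-c2nc3ccccc3o2)cc1)c1ccc(C(F)(F)F)cc1` gives > 63000 nM, again a limit.

All three measured compounds sit at the same limit in this assay, as the limit of > 63000 nM in this assay, at which 3 of the 3 values shown sit, records, so none of them yields a number that could be compared with another. The change from compound 2 to compound 1 is methoxy in place of trifluoromethyl on an aromatic carbon; the step that the two limits leave unreadable from compound 2 to compound 1 cannot be read, since both ends are limits. Compound 2 and compound 3 are built from the same atoms joined differently; the difference between the two cores is not broken down here. Compound 4 `COc1ccc(S(=O)(=O)Nc2ccc(-c3nc4ccccc4o3)cc2)cc1` has not yet been measured. It differs from compound 3 by methoxy in place of trifluoromethyl on an aromatic carbon, the same change as the one made earlier. Compound 4 is expected to move by a step that the limit leaves unreadable from compound 3 to compound 4 because compound 3 gives > 63000 nM, and the earlier instance of this change gave no readable step. For compound 4 in this assay the estimate is 90000 nM, most likely reported once more only as a limit.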

Compound 4, half-maximal inhibitory concentration: > 63000 nM
Compound 4 ended at the assay's limit (the forecaster's own chance of this, stated with the estimate: 85%); the middle value is on the limit's open side.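

No step can be read between compound 3 and compound 4 in this assay, as both results are limits rather than numbers: the limit of > 63000 nM in this assay, at which 4 of the 4 values shown sit.

The compounds shown leave open whether methoxy in place of trifluoromethyl changes inhibition at all, and whether either core can give a measurable value in this assay.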